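Pentan-3-ylamino versus diethylamino on two bicyclic cores

A few compounds are considered here, and "the series" means these few. Any claim that something is new, unique, unknown or untested is made for them only; others in the source may bear on it.

Measured in an assay on cell membranes for displacement of a labelled ligand from corticotropin-releasing factor receptor 1 (Rattus norvegicus) (a higher number here means a weaker inhibitor, a lower number a stronger inhibitor), so far:
compound 1 `CCC(CC)Nc1nc(C)nc2c(-c3c(C)cc(N(C)C)nc3C)c(C)nn12` gives 25.6 nM
compound 2 `CCN(CC)c1nc(C)nc2c(-c3cnc(OC)cc3C)c(C)nn12` gives 14.5 nM
compound 3 `CCN(CC)c1nc(C)nc2c(-c3c(C)cc(N(C)C)nc3C)c(C)nn12` gives 58 nM

Compound 4 `CCC(CC)Nc1nc(C)nc2c(-c3cnc(OC)cc3C)c(C)nn12` is not yet measured. Against compound 2 it shows ((pentan-3-yl)amino in place of diethylamino on an aromatic carbon). The same change, ((pentan-3-yl)amino in place of diethylamino on an aromatic carbon), separates compound 3 from compound 1, where it gave a 2.3-fold lower number from compound 3 to compound 1 (0.36 log units; beyond the scatter); the place lines of the two changes read the same word for word. How the core of compound 2 differs from that of compound 3 is not broken down here. Going by the values given here, with only this single precedent, the step from compound 2 to compound 4 in this assay is expected to be about a 2.2-fold lower number from compound 2 to compound 4 (0.35 log units; beyond the scatter), resting on a 2.3-fold lower number from compound 3 to compound 1 (0.36 log units; beyond the scatter). Compound 4 is therefore estimated at 6.5 nM, with 3 nM to 15 nM as the expected range.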

Compound 4, half-maximal inhibitory concentration: 3 nM
The estimate for compound 4 lay 2.2-fold (0.34 log units) above the measured number; the measured number falls inside the stated range.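

In this assay (pentan-3-yl)amino in place of diethylamino gives a 4.8-fold lower number from compound 2 to compound 4 (0.68 log units; beyond the scatter) and so lowers the number on the core of compound 2, as it does on the core of compound 3. The sizes of the two steps cannot be told apart: the same change on two cores in this assay, a 2.3-fold lower number (0.36 log units; beyond the scatter) from compound 3 to compound 1 and a 4.8-fold lower number (0.68 log units; beyond the scatter) from compound 2 to compound 4, 2.1-fold (0.33 log units) apart, within the scatter of two such steps. This shows the direction of the change carrying over between these two cores, but it does not show a larger effect on either core, and two cores cannot establish a rule for the series.

Still open, going by these compounds, is whether other amines on the same aromatic carbon, such as heptan-4-ylamino or cyclopropylmethylamino, follow the same course. Also open, on these data alone, is whether the step holds on a core carrying chloro in place of the methoxy group.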